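Swapping the ring on the amide nitrogen of compound 3

The compounds below may be only part of what the source reports. "The series", "measured", "known", "first", "only" and "open" are said of these compounds alone.

Measured so far:
- compound 1, `Cn1ccc2ccc(-c3cc(Nc4ccccc4S(N)(=O)=O)cc4nccnc34)cc21`: in an assay for inhibition of 6-phosphofructo-2-kinase/fructose-2,6-bisphosphatase 3 (Homo sapiens), read by ADP-Glo, with a stated time of 2 h (a lower number here means a stronger inhibitor, a higher number a weaker inhibitor), compound 1 gives 265 nM
- compound 2, `Cn1cc(CNS(=O)(=O)c2ccccc2Nc2cc(-c3ccc4ccn(C)c4c3)c3nccnc3c2)cn1`: in this assay compound 2 gives 38 nM
- compound 3, `CN1CCC(NC(=O)c2ccncc2Nc2cc(-c3ccc4ccn(C)c4c3)c3nccnc3c2)CC1`: in this assay compound 3 gives 38 nM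

Compound 3 stands level with compound 2 at the digits shown, and the two together have the lowest numbers of the three; compound 1 is the one furthest away, with the higher number. Going by the values given here, the only step measured within the set, a 7.0-fold lower number from compound 1 to compound 2 (0.84 log units; beyond the scatter), concerns a group added on a sulfonamide nitrogen, a part that compound 3 does not carry at all.

Compound 4, `CC(=O)N1CCC(NC(=O)c2ccncc2Nc2cc(-c3ccc4ccn(C)c4c3)c3nccnc3c2)C1`, differs from compound 3 at the amide: 1-acetylpyrrolidin-3-yl in place of 1-methylpiperidin-4-yl on an amide-type nitrogen. Among the compounds with values here, no measured pair shows what happens when the ring on this amide nitrogen is exchanged, so the data give no direct guide. Within the data shown here, the one measured step, a 7.0-fold lower number from compound 1 to compound 2 (0.84 log units; beyond the scatter), shows only that a change in the outer part of a related compound moved the number modestly. For compound 4 the step from compound 3 is therefore expected to be small, a 1.6-fold higher number from compound 3 to compound 4 (0.20 log units; within the scatter), most likely within the scatter in either direction. Compound 4 is estimated at 60 nM in this assay, with a range from 20 nM to 200 nM.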

Compound 4, half-maximal inhibitory concentration: 105 nM
The estimate for compound 4 lay 1.8-fold (0.24 log units) below the measured number, within the range that was stated.
By their numbers in this assay, from the lowest: compounds 2 and 3 (each within the scatter of the next); then compound 4; then compound 1.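

The ring on the amide nitrogen affects the result: in this assay, putting 1-acetylpyrrolidin-3-yl in place of 1-methylpiperidin-4-yl gives a 2.8-fold higher number from compound 3 to compound 4 (0.44 log units; beyond the scatter), so this position does not tolerate every ring equally. The exchange alters more than one feature at once, since a six-membered ring gives way to a five-membered one, and the entering group brings an acetyl with its oxygen and a double bond outside aromatic rings, while the computed counts of hydrogen-bond donors and acceptors stay the same. No measurement available here connects the higher number with any one of these features.

The compounds shown leave open whether ring size or the group on the ring nitrogen matters more, a question that 1-acetylpiperidin-4-yl or 1-methylpyrrolidin-3-yl on the same amide nitrogen could help to separate. They also leave open how the number would respond to a group without a ring at this position, such as a short chain ending in an amine or a carboxylic acid.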